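Swapping the aryl group on the sulfonyl sulfur

The source may hold more compounds than are shown below. What is called first, only, known or untested is meant among the compounds shown, and "the series" means these compounds.

Among the measured compounds shown here, compound 2 `CN1CCN(c2ccc3[nH]nc(S(=O)(=O)c4c(Cl)cccc4Cl)c3c2)CC1` gives 40 nM in a functional assay on HeLa cells for antagonist activity at 5-hydroxytryptamine receptor 6 (Homo sapiens) (a lower number here means a stronger inhibitor, a higher number a weaker inhibitor), the lower of the two numbers measured so far. Compound 1 `COc1cccc(S(=O)(=O)c2n[nH]c3ccc(N4CCN(C)CC4)cc23)c1` gives 57 nM there, and the step of a 1.4-fold lower number from compound 1 to compound 2 (0.15 log units; within the scatter) shows the two within the scatter. Compound 3 `COc1ccc(S(=O)(=O)c2n[nH]c3ccc(N4CCN(C)CC4)cc23)cc1` carries the change (4-methoxyphenyl in place of 2,6-dichlorophenyl on a sulfonyl sulfur). For the measured compounds named here, the one step that bears on it, the exchange of a methoxyphenyl for the dichlorophenyl between compound 1 and compound 2, stayed within the scatter, so no change beyond the scatter is expected for compound 3, and the step is estimated as a 1.3-fold higher number from compound 2 to compound 3 (0.10 log units; within the scatter). Compound 3 is expected to give about 50 nM, between 20 nM and 150 nM.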

Compound 3, half-maximal inhibitory concentration: 544 nM
Compound 3: the middle estimate sits 11-fold (1.04 log units) below what was measured, outside the stated range (above it).
By their numbers in this assay, from the lowest: compounds 2 and 1 (each within the scatter of the next); then compound 3.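

Changing the aryl group on the sulfonyl sulfur can matter a great deal: 4-methoxyphenyl gives a far weaker inhibitor than the dichlorophenyl group does (a 14-fold higher number from compound 2 to compound 3 (1.13 log units; beyond the scatter)). It also falls short of 3-methoxyphenyl, which has the same atoms (a 9.5-fold higher number from compound 1 to compound 3 (0.98 log units; beyond the scatter)), so where the methoxy stands on the ring counts, not merely its presence. Nothing measured here gives a reason for this loss. Still open, on these data alone, is whether an amine or a carboxylic acid in the methoxy's place would keep the number low or raise it as well.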